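The source may report more compounds than this note shows. Statements on the series, on what has been measured and on what is new or still open speak of the compounds shown alone.

Working notes on the series. Compound 1 `CC(=O)OC(C)n1cnc2c(Cl)nc(I)nc21` is tested in a functional assay on HT-29 cells (Homo sapiens) for inhibition (a higher number here means a weaker inhibitor, a lower number a stronger inhibitor), where compound 1 gives 6420 nM. Compound 2 `CC(O)n1cnc2c(Cl)nc(I)nc21` carries the change (hydrogen in place of acetyl on an oxygen on a saturated carbon). In this assay compound 2 reaches only the limit of the assay, > 500000 nM. The step of an at least 77-fold higher number from compound 1 to compound 2 (1.89 log units; beyond the scatter) is read against (the limit of > 500000 nM in this assay, at which 2 of the 3 values shown sit), which leaves its true size open. Compound 3 `CC(=O)OC(C)n1cnc2c(S)nc(F)nc21` has a different core; the difference between the core of compound 1 and the core of compound 3 is not broken down here. In this assay compound 3 sits at the limit of the assay, > 500000 nM. Compound 4 `CC(O)n1cnc2c(S)nc(F)nc21` is not yet measured and differs from compound 3 by hydrogen in place of acetyl on an oxygen on a saturated carbon, the same change that was made from compound 1 to compound 2. Compound 4 is expected to show the step that the limit leaves unreadable from compound 3 to compound 4, because the same change produced an at least 77-fold higher number from compound 1 to compound 2 (1.89 log units; beyond the scatter). Compound 3 moreover stands at the limit of the assay, > 500000 nM, which bears on the expectation. Compound 4 is accordingly expected to give about 1000000 nM, between 500000 nM and 5000000 nM, most likely reported only as a limit.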

Compound 4, half-maximal inhibitory concentration: > 500000 nM
Compound 4: only a limit was reported; the forecaster's own chance of this, stated with the estimate: 95%; the middle value is on the limit's open side.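

No step can be read from compound 3 to compound 4 in this assay, as both compounds are reported only as limits: the limit of > 500000 nM in this assay, at which 3 of the 4 values shown sit.

The compounds shown leave open what size, if any, the acetoxy to hydroxy change has on the core of compound 3 in this assay.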